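The source may hold more compounds than are shown below. What is called first, only, known or untested is meant among the compounds shown, and "the series" means these compounds.

Two ureas built on the same core are compared in an assay on microsomes from intestine for inhibition of acyl-CoA:cholesterol acyltransferase (Oryctolagus cuniculus); on this read-out higher numbers stand for weaker inhibition and lower numbers for stronger inhibition. Compound 1 `CC(C)c1cccc(C(C)C)c1NC(=O)Nc1nn[nH]n1` reaches only the limit of this assay and returns > 10000 nM, which is a limit of the measurement and not a number; this is the situation described by the limit of > 10000 nM in this assay, at which 1 of the 2 values shown sits. Among the compounds with values here, compound 2 `CCCCN1NN=C(NC(=O)Nc2c(C(C)C)cccc2C(C)C)N1` gives 92 nM in this assay, the only actual number among the two values shown. Compound 3 `CCCCCCN1NN=C(NC(=O)Nc2c(C(C)C)cccc2C(C)C)N1` has not yet been measured. It differs from compound 2 by ethyl in place of hydrogen on a saturated chain carbon, four bonds along the chain from an amine nitrogen in a ring. Within the data shown here, no step between measured compounds bears on such a chain extension, so the expected change from compound 2 to compound 3 in this assay, a 1.1-fold higher number from compound 2 to compound 3 (0.04 log units; within the scatter), is taken to lie within the usual scatter, in no particular direction. Compound 3 is therefore expected to give about 100 nM, between 30 nM and 350 nM.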

Compound 3, half-maximal inhibitory concentration: 73 nM
For compound 3 the middle estimate is 1.4-fold (0.14 log units) above the measured one; low and high end bracket the measured number.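

In this assay, ethyl in place of hydrogen on a saturated chain carbon, four bonds along the chain from an amine nitrogen in a ring, gives a 1.3-fold lower number from compound 2 to compound 3 (0.10 log units; within the scatter) as the first step read at this position. The chain on the core of compound 2 can therefore carry this extra ethyl without a shift in the read-out beyond the scatter, so this place accepts added chain length, at least to this extent. Nothing among the values shown gives a reason for this outcome.

Going by these compounds, whether a still longer chain, or a chain ending in a carboxylic acid or an amine, would keep the read-out in the same range remains open. A single step also leaves open whether a shorter chain at this place would behave the same way.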